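The source may hold more compounds than are shown below. What is called first, only, known or untested is meant among the compounds shown, and "the series" means these compounds.

Compound 3, `COc1ccccc1CCCN1CCC(COC(c2ccccc2)c2ccccc2)CC1`, was tested in a functional assay on cells (T-cell line, Homo sapiens) for inhibition (a lower number here means a stronger inhibitor, a higher number a weaker inhibitor), where compound 3 gives 2400 nM. Among the three measured compounds this places compound 3 as the second highest number. Its nearest neighbour is compound 1, `COc1ccc(CCCN2CCC(CNC(c3ccccc3)c3ccccc3)CC2)cc1`, which in this assay gives 2800 nM, a gap that sits within the scatter, so the two cannot be told apart. The furthest is compound 2, `COc1ccc(CCCN2CCC(COC(c3ccccc3)c3ccc(Cl)cc3)CC2)cc1`, which in this assay gives 200 nM, a lower number that lies beyond the scatter. For the measured compounds named here, none of the measured compounds differ from one another in a single place, so no measured step guides the move to compound 4, `CCCCCCCCCN1CCC(COC(c2ccccc2)c2ccccc2)CC1`. The change is hexyl in place of 2-methoxyphenyl on a saturated chain carbon, three bonds along the chain from an amine nitrogen in a ring. Going by the values given here, with no comparable step among the measured compounds, the expectation rests on the bare structures: the loss of the aromatic ring and its acceptor is expected to weaken inhibition modestly, so the step in this assay is estimated at a 1.9-fold higher number from compound 3 to compound 4 (0.27 log units; within the scatter), close to the edge of the scatter. Compound 4 is therefore expected to give about 4500 nM in this assay, within a range from 1200 nM to 15000 nM.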

Compound 4, half-maximal inhibitory concentration: 700 nM
Compound 4: the middle estimate sits 6.4-fold (0.81 log units) above what was measured; measured number outside the range, below it.
By their numbers in this assay, from the lowest: compound 2; then compound 4; then compounds 3 and 1 (each within the scatter of the next).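

In this assay, hexyl in place of 2-methoxyphenyl on a saturated chain carbon, three bonds along the chain from an amine nitrogen in a ring, gives a 3.4-fold lower number from compound 3 to compound 4 (0.54 log units; beyond the scatter). This is the only single-place comparison among the compounds shown, and it shows that inhibition at this position does not depend on keeping the aromatic ring or its hydrogen-bond acceptor, since the hexyl compound, with neither, gives the lower number. No measurement at hand accounts for this step.

This one pair cannot separate the loss of the ring from the loss of the methoxy group or from the gain of the open chain. On these data alone, whether a cyclohexyl ring in the same place would behave like hexyl, and whether a longer chain such as octyl would extend the step, remains open.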